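The source may report more compounds than this note shows. Statements on the series, on what has been measured and on what is new or still open speak of the compounds shown alone.

Measured so far:
- Compound 1 `CCn1cc(-c2nc3ccccc3[nH]2)c(=O)c2cc(F)c(N3CCNCC3)nc21`: 4100 nM
- Compound 2 `CCn1cc(-c2nc3ccc([N+](=O)[O-])cc3[nH]2)c(=O)c2cc(F)c(N3CCNC(C)C3)c(F)c21`: 1100 nM

In a functional assay on Bel-7402 cells (Homo sapiens) for cytotoxicity, read by MTT assay, with a stated time of 48 h (on this read-out lower numbers stand for stronger inhibition and higher numbers for weaker inhibition), compound 1 gives 4100 nM, the higher of the two numbers and therefore the weaker result. Compound 2 gives 1100 nM, and the gap between the two lies beyond the usual scatter.

The next compound is compound 3 `CCn1cc(-c2nc3ccc(N)cc3[nH]2)c(=O)c2cc(F)c(N3CCNCC3)nc21`, which keeps the core of compound 1 and differs from it in one place: amino in place of hydrogen on an aromatic carbon. It has amino in place of hydrogen on an aromatic carbon, on a six-membered aromatic ring of carbon only that is part of a fused or bridged system of two rings.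

Going by the values given here, no two measured compounds differ in one place only, so the data offer no direct guide to this step. Compound 1 and compound 2 differ in several places, and the value of compound 2 1100 nM cannot be assigned to any one of them. Only a modest move towards stronger inhibition is therefore expected, and it may not clear the scatter. The estimated change is a 1.5-fold lower number from compound 1 to compound 3 (0.17 log units; within the scatter). For compound 3, the expected value in this assay is 2800 nM, with an estimated range from 900 nM to 8000 nM.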

Compound 3, half-maximal inhibitory concentration: 93300 nM
Compound 3: the middle estimate sits 33-fold (1.52 log units) below what was measured; the whole stated range lies below it.
By their numbers in this assay, from the lowest: compound 2; then compound 1; then compound 3.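

In this assay, the change of amino in place of hydrogen gives a 23-fold higher number from compound 1 to compound 3 (1.36 log units; beyond the scatter) and so moves strongly towards weaker inhibition, well beyond the scatter. Going by these compounds alone, this is the first change that can be read on its own, since compound 1 and compound 2 differ in several places and could not tie any effect to a single site. It shows that, on the core of compound 1, this aromatic carbon of the six-membered aromatic ring of carbon only is not indifferent to substitution, although nothing available explains why a single amino group has so large an effect.

The compounds shown leave open whether the loss belongs to the amino group itself or would follow any group placed on this carbon, a question that a methoxy group, a chlorine atom or an acetamide at the same place would help to settle. They also leave open whether amino in place of hydrogen would have a similar effect on the core of compound 2.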